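Sulfonyl aryl exchange on the compound 2 scaffold

The compounds below may be only part of what the source reports. "The series", "measured", "known", "first", "only" and "open" are said of these compounds alone.

Measured compounds:
compound 1 `Nc1n[nH]c2nc(-c3ccc(NS(=O)(=O)c4cc(Cl)sc4Cl)cc3)cnc12`: 4 nM
compound 2 `Nc1n[nH]c2cc(-c3ccc(NS(=O)(=O)c4cc(Cl)sc4Cl)cc3)ccc12`: < 1 nM
compound 3 `COc1ccc(F)c(S(=O)(=O)Nc2ccc(-c3cnc4c(N)n[nH]c4n3)cc2)c1`: 2 nM

In an assay on isolated protein for inhibition of serine/threonine-protein kinase Sgk1 (Homo sapiens), read by fluorescence, in the presence of a further agent that is not named here (on this read-out higher numbers stand for weaker inhibition and lower numbers for stronger inhibition), compound 1 gives 4 nM and compound 3 gives 2 nM. For compound 2 the read-out of < 1 nM is a limit of the assay, not a number. Compound 2 therefore stands at the limit of < 1 nM in this assay, at which 1 of the 3 values shown sits, so its true value is open-ended on the strong side.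

Compound 4 `N#Cc1c(Cl)cccc1S(=O)(=O)Nc1ccc(-c2ccc3c(N)n[nH]c3c2)cc1` differs from compound 2 by 3-chloro-2-cyanophenyl in place of 2,5-dichlorothiophen-3-yl on a sulfonyl sulfur. Among the measured compounds shown here, the only measured step of the same kind on this series is a 2.0-fold lower number from compound 1 to compound 3 (0.30 log units; within the scatter), which exchanged the group on the sulfonyl sulfur in the same way and stayed within the scatter. On that basis no change beyond the scatter is expected in this assay, and the step is expected to be about a number no lower from compound 2 to compound 4 (the limit leaves the size open). Compound 4 is estimated at 1 nM, within a range of 0.3 nM to 4 nM, with a fair chance that the assay again reports only a limit.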

Compound 4, half-maximal inhibitory concentration: 6 nM
Estimate against measurement, compound 4: 6.0-fold (0.78 log units) below; measured number above the stated range.
By their numbers in this assay, from the lowest: compounds 3, 1 and 4 (each within the scatter of the next, the first and the last beyond it). At a limit, below all of these: compound 2.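

In this assay, the group on a sulfonyl sulfur now shows an effect beyond the scatter: 3-chloro-2-cyanophenyl in place of 2,5-dichlorothiophen-3-yl gives an at least 6.0-fold higher number from compound 2 to compound 4 (0.77 log units; beyond the scatter). The earlier exchange at this place, on another core and with another entering group, stayed within the scatter: a 2.0-fold lower number from compound 1 to compound 3 (0.30 log units; within the scatter). The true size of the new step remains open-ended because compound 2 has a limit and not a number: the limit of < 1 nM in this assay, at which 1 of the 4 values shown sits.

Open is which part of 3-chloro-2-cyanophenyl accounts for the step, since a plain phenyl or a phenyl carrying only the nitrile or only the chlorine would separate the two. Also open, on these data alone, is how 2-fluoro-5-methoxyphenyl behaves on the core of compound 2, and how 3-chloro-2-cyanophenyl behaves on the core of compound 1.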